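Swapping 4-aminophenyl for phenoxymethyl on the triple bond

The source may report more compounds than this note shows. Statements on the series, on what has been measured and on what is new or still open speak of the compounds shown alone.

Compound 1 `COc1cccc(C#Cc2cc(Cl)cn3c([N+](=O)[O-])c(CS(=O)(=O)c4ccccc4)nc23)c1` and compound 2 `Nc1ccc(C#Cc2cc(Cl)cn3c([N+](=O)[O-])c(CS(=O)(=O)c4ccccc4)nc23)cc1` share one core, and both were tested in an ADME assay on HepG2 cells (Homo sapiens) for cytotoxicity, read by MTT assay, with a stated time of 72 h; a higher number here means that more compound is tolerated, a lower number that less compound is tolerated. Compound 1 gives > 3900 nM, which is a limit and not a number. Compound 2 gives > 3900 nM, which is also only a limit. So compound 2 has no readable value, and compound 1 and compound 2 together rest on (the limit of > 3900 nM in this assay, at which 2 of the 2 values shown sit). Among the compounds with values here, the one measured step is a step that the two limits leave unreadable from compound 1 to compound 2, so it offers no size to carry forward.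

Compound 3 `O=[N+]([O-])c1c(CS(=O)(=O)c2ccccc2)nc2c(C#CCOc3ccccc3)cc(Cl)cn12` keeps the core of compound 2 and alters only the group on a triple-bonded carbon, with phenoxymethyl in place of 4-aminophenyl on a triple-bonded carbon. Within the data shown here, no measured step covers this change, so no step beyond the scatter is expected in this assay, and no direction can be named. The expectation leans on the limit of compound 2, > 3900 nM. The estimated step is a step that the limit leaves unreadable from compound 2 to compound 3. For compound 3 the expected value is 5000 nM, with an estimated range from 2500 nM to 12000 nM.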

Compound 3, half-maximal cytotoxic concentration: 8400 nM
Beside the measured number, compound 3's estimate is 1.7-fold (0.23 log units) below it, within the range that was stated.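

The steps from compound 1 and from compound 2 to compound 3 cannot be read, since compound 1 and compound 2 stand only as limits in this assay: the limit of > 3900 nM in this assay, at which 2 of the 3 values shown sit.

The compounds shown leave open whether 3-methoxyphenyl, 4-aminophenyl and phenoxymethyl on the triple-bonded carbon differ at all in how much compound is tolerated in this assay.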